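Working notes: nitro to methoxy on an aromatic carbon

This account rests on a few compounds, and the source may have more. Where it says the series, first, only, none or still open, it means among the compounds named here.

Values measured in an ADME assay on HEK293 cells (Homo sapiens) for cytotoxicity, read by MTT assay, with a stated time of 48 h (on this read-out lower numbers stand for stronger inhibition and higher numbers for weaker inhibition), stand below.

- compound 1 `CC1(C)CCCC2=CC=C(C=O)CC[C@]21C` gives 696000 nM
- compound 2 `C=C1CCC[C@]2(C)CCC(c3cn(-c4cccc([N+](=O)[O-])c4)nn3)=CC[C@@]12C` gives 699000 nM
- compound 3 `C=C1CCC[C@]2(C)CCC(c3cn(CC(=O)Nc4ccc(C)cc4)nn3)=CC[C@@]12C` gives 622000 nM

Compound 2 at 699000 nM stands within the scatter of both other compounds, so no order can be read among the three numbers. Within the data shown here, the series holds no pair of measured compounds that differ in one place, and so no single change has yet been measured directly in this assay here.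

The compound still to be measured is compound 4 `C=C1CCC[C@]2(C)CCC(c3cn(-c4cccc(OC)c4)nn3)=CC[C@@]12C` and its difference from compound 2 reads methoxy in place of nitro on an aromatic carbon (methoxy in place of nitro on an aromatic carbon, meta to a large group). The same difference can be read as 3-nitrophenyl to 3-methoxyphenyl.

No step beyond the scatter is expected in this assay in either direction. This expectation rests on compound 3 at 622000 nM which carries a different side chain on the core shared with compound 2 and still lies within the scatter of it. Three compounds are a thin basis, so the range is kept wide. The estimate means a 1.1-fold lower number from compound 2 to compound 4 (0.04 log units; within the scatter) and this expected step lies within the scatter. For compound 4 the expected value is 640000 nM with an estimated range of 380000 nM to 950000 nM in this read-out.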

Compound 4, half-maximal inhibitory concentration: 734000 nM
Compound 4: middle estimate off by 1.1-fold (0.06 log units), on the low side, and the stated range covers the measured number.
By their numbers in this assay, from the lowest: compounds 3, 1, 2 and 4 (each within the scatter of the next).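

Working notes, continued: the change from 3-nitrophenyl to 3-methoxyphenyl gives the series its first direct single-place comparison. In this assay the step is a 1.1-fold higher number from compound 2 to compound 4 (0.02 log units; within the scatter) and thus gives no measurable separation between the two groups. Among these compounds, at this aromatic carbon, meta to a large group, nitro and methoxy therefore cannot be told apart on this read-out, although the earlier compounds could say nothing about this position on its own. No supporting data are available to explain this result.

Among the compounds shown here, the pair covers only two groups at this position, so it remains open whether an amine, a carboxylic acid or a longer chain on the same aromatic carbon would give a step beyond the scatter in this assay. From the compounds shown here alone, it also remains open whether methoxy in place of nitro would read the same way on another carbon of the six-membered aromatic ring.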